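Two chlorines on the benzyl arm of compound 1

The source may hold more compounds than are shown below. What is called first, only, known or untested is meant among the compounds shown, and "the series" means these compounds.

Compound 1 `Cc1cc(N2CC[C@@H](C)[C@@H](N(C)c3ncnc4[nH]ccc34)C2)n2nc(SCC3CC3)nc2n1` is the starting point. In a functional assay on MGC-803 cells (Homo sapiens) for inhibition, read by MTT assay, with a stated time of 72 h (a lower number here means a stronger inhibitor, a higher number a weaker inhibitor), compound 1 gives 9540 nM, the lowest of the three numbers measured, although its distance from compound 2 `Cc1cc(N2CC[C@@H](C)[C@@H](N(C)c3ncnc4[nH]ccc34)C2)n2nc(SCc3ccc(F)cc3)nc2n1` is small: compound 2 gives 11900 nM, and the step of a 1.2-fold higher number from compound 1 to compound 2 (0.10 log units; within the scatter). Compound 3 `Cc1cc(N2CC[C@@H](C)[C@@H](N(C)c3ncnc4[nH]ccc34)C2)n2nc(SCc3ccc(F)c(Cl)c3)nc2n1` gives 52000 nM, and the step of a 5.5-fold higher number from compound 1 to compound 3 (0.74 log units; beyond the scatter).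

Compound 4 `Cc1cc(N2CC[C@@H](C)[C@@H](N(C)c3ncnc4[nH]ccc34)C2)n2nc(SCc3cc(Cl)ccc3Cl)nc2n1` has not yet been measured. Its difference from compound 1 is 2,5-dichlorophenyl in place of cyclopropyl on a saturated chain carbon bound to a sulfur.

Among the measured compounds shown here, two measured steps bear on this. Swapping the cyclopropyl for a 4-fluorophenyl changed little, as a 1.2-fold higher number from compound 1 to compound 2 (0.10 log units; within the scatter) shows, whereas adding a chloro onto that aromatic ring gave a 4.4-fold higher number from compound 2 to compound 3 (0.64 log units; beyond the scatter). Compound 4 carries two chlorines and no fluorine on its aromatic ring, so a weaker result than compound 1 is expected, at least as large as the step to compound 3 and possibly larger. Accordingly the expected step is a 4.7-fold higher number from compound 1 to compound 4 (0.67 log units; beyond the scatter). Compound 4 is estimated at 45000 nM, with a range from 14000 nM to 140000 nM.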

Compound 4, half-maximal inhibitory concentration: 9850 nM
For compound 4 the middle estimate is 4.6-fold (0.66 log units) above the measured one; the whole stated range lies above it.
By their numbers in this assay, from the lowest: compounds 1, 4 and 2 (each within the scatter of the next); then compound 3.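

The 2,5-dichlorobenzyl arm on the sulfur sits level with the smaller arms: in this assay the steps are a 1.0-fold higher number from compound 1 to compound 4 (0.01 log units; within the scatter) and a 1.2-fold lower number from compound 2 to compound 4 (0.08 log units; within the scatter), so a larger ring with two chlorines does not by itself raise the number. Chlorine on the ring therefore does not go with a weaker result in every case, as a 5.3-fold lower number from compound 3 to compound 4 (0.72 log units; beyond the scatter) shows, and among these aromatic arms compound 3 is the one that stands apart. No measurement here accounts for the gap between these two halogenated rings.

Going by these compounds, it remains open whether a benzyl ring bearing an amine or a carboxylic acid would fall with compounds 1, 2 and 4 or with compound 3. The same question holds for a longer alkyl chain on the sulfur.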